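This account rests on a few compounds, and the source may have more. Where it says the series, first, only, none or still open, it means among the compounds named here.

Measured compounds in a functional assay on SNB-75 cells (Homo sapiens) for inhibition, read by sulforhodamine B assay, with a stated time of 48 h, tested at 10 uM; a higher number here means more inhibition at the concentration tested (going by the name of the read-out), a lower number less inhibition:
- compound 1 `Brc1cn2ccnc2c(-c2ccc3ncn(C4CCCCC4)c3c2)n1` gives 21.3%
- compound 2 `c1ccc(-c2cn3ccnc3c(-c3ccc4ncn(C5CCCCC5)c4c3)n2)cc1` gives 44.4%

Compound 2 stands highest of the two numbers; the step of a number 23.1 percentage points higher from compound 1 to compound 2 (beyond the scatter) lies beyond the scatter. Compound 3 `COc1ccc(-c2cn3ccnc3c(-c3ccc4ncn(C5CCCCC5)c4c3)n2)cc1` is the next member, not yet measured. The change is methoxy in place of hydrogen on an aromatic carbon. Among the measured compounds shown here, no measured step varies the phenyl ring itself; the one step available concerns the group on the core, so it bears only loosely on this change. Without a precedent, the expectation for compound 3 is a step within the scatter, a number 3.6 percentage points higher from compound 2 to compound 3 (within the scatter). The estimated value for compound 3 is 48%, with a range from 30% to 66%.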

Compound 3, a percentage reported as inhibition, at one concentration (the size of the read-out at that concentration, not a potency): -26.3%
Estimate against measurement, compound 3: 74.3 percentage points above; the measured number lies below the stated range.
By their numbers in this assay, from the lowest: compound 3; then compound 1; then compound 2.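

In this assay, the outer phenyl ring proves sensitive to substitution: methoxy para to a large group brings a number 70.7 percentage points lower from compound 2 to compound 3 (beyond the scatter) in a single change. The gain seen on going from bromo to phenyl does not carry over to the substituted ring, since 4-methoxyphenyl in place of bromo brings a number 47.6 percentage points lower from compound 1 to compound 3 (beyond the scatter) and falls short of bromo itself. Nothing available explains this drop.

Going by these compounds, whether the loss is specific to methoxy remains open. A hydroxyl, a fluorine or an amine at the same place would test this.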